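Swapping the aryl group on a triazole-linked butenolide scaffold

The source may hold more compounds than are shown below. What is called first, only, known or untested is meant among the compounds shown, and "the series" means these compounds.

Measured so far in a functional assay on MCF7 cells (Homo sapiens) for antiproliferative activity, read by MTT assay, with a stated time of 72 h; a higher number here means a weaker inhibitor, a lower number a stronger inhibitor:
compound 1 `O=C1O/C(=C\Cn2cc(-c3cc(F)cc(F)c3)nn2)C(OCc2ccccc2)=C1OCc1ccccc1`: > 100000 nM
compound 2 `CCCCCc1ccc(-c2cn(C/C=C3\OC(=O)C(OCc4ccccc4)=C3OCc3ccccc3)nn2)cc1`: > 100000 nM
compound 3 `CCCCCc1ccc(-c2cn(C[C@H](O)[C@H]3OC(=O)C(OCc4ccccc4)=C3OCc3ccccc3)nn2)cc1`: 9010 nM

Among the compounds with values here, compound 3 is the only compound here with a number in this assay; compound 3 gives 9010 nM. Compound 1 shows only a limit in this assay. Compound 2 likewise shows only a limit in this assay. The single measured step among these three, a step that the two limits leave unreadable from compound 1 to compound 2, cannot be read because the limit of > 100000 nM in this assay, at which 2 of the 3 values shown sit, hides both ends of it.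

Compound 4 `O=C1O[C@H]([C@@H](O)Cn2cc(-c3cc(F)cc(F)c3)nn2)C(OCc2ccccc2)=C1OCc1ccccc1` differs from compound 3 by 3,5-difluorophenyl in place of 4-pentylphenyl on an aromatic carbon. Within the data shown here, this is the mirror image of the one measured step, and that step is unreadable, so the data give neither the size nor the direction of the change to expect in this assay. With no usable guide, compound 4 is estimated near 20000 nM, spanning 4000 nM to 100000 nM, so that a 2.2-fold higher number from compound 3 to compound 4 (0.35 log units; beyond the scatter) is expected as a loose guess rather than a reading of any measured step.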

Compound 4, half-maximal inhibitory concentration: 27700 nM
For compound 4 the middle estimate is 1.4-fold (0.14 log units) below the measured one, within the range that was stated.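

At this position, on an aromatic carbon of a five-membered aromatic ring with 3 nitrogen, 3,5-difluorophenyl in place of 4-pentylphenyl gives, in this assay, a 3.1-fold higher number from compound 3 to compound 4 (0.49 log units; beyond the scatter). Within the data shown here, this is the first readable measure of this exchange, and it shows that the choice of aryl group moves the number modestly on the shared core of this pair, with both compounds giving a number rather than a limit. The same exchange from compound 1 to compound 2 cannot be read, because both compounds show only a limit of the assay: the limit of > 100000 nM in this assay, at which 2 of the 4 values shown sit.

With only two aryl groups compared, the compounds shown do not separate the contribution of the pentyl chain from that of the two fluorine atoms. From the compounds shown here alone, how a shorter alkyl chain, a single fluorine atom or an amine on the phenyl ring would read here remains open.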